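Hydroxyphenyl placement: working notes toward compound 4

The source may hold more compounds than are shown below. What is called first, only, known or untested is meant among the compounds shown, and "the series" means these compounds.

Measured compounds:
compound 1 `Oc1cccc(-c2cc(-c3ccccc3F)cc(-c3cccc(O)c3)n2)c1`, 4370 nM
compound 2 `Oc1cccc(-c2cc(-c3cccc(F)c3)cc(-c3cccc(O)c3)n2)c1`, 21300 nM
compound 3 `Oc1cccc(-c2cc(-c3ccccc3C(F)(F)F)cc(-c3ccccc3O)n2)c1`, 5680 nM

All numbers come from a functional assay on T47D cells (Homo sapiens) for inhibition; a lower number here means a stronger inhibitor, a higher number a weaker inhibitor. Among the three measured compounds, compound 3 gives the second highest number; compound 1 sits nearest, with a gap that lies within the scatter, while compound 2 lies furthest, beyond the scatter. Going by the values given here, the only single-point step measured so far, a 4.9-fold higher number from compound 1 to compound 2 (0.69 log units; beyond the scatter), concerns the fluorophenyl group and not a hydroxyphenyl group, so it does not bear directly on the change considered here.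

Compound 4 `Oc1cccc(-c2cc(-c3ccccc3C(F)(F)F)cc(-c3cccc(O)c3)n2)c1` differs from compound 3 by 3-hydroxyphenyl in place of 2-hydroxyphenyl on an aromatic carbon. Among the compounds with values here, no measured step covers a move of this hydroxyl. What can be said is that compound 4 carries only 3-hydroxyphenyl groups, as compound 1 does, and the number of compound 1 in this assay lies within the scatter of that of compound 3. On that basis a step of a 1.3-fold lower number from compound 3 to compound 4 (0.10 log units; within the scatter) is expected, which amounts to no shift beyond the scatter. For compound 4 the estimate in this assay is 4500 nM, with a range from 1500 nM to 13000 nM.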

Compound 4, half-maximal inhibitory concentration: 4350 nM
Compound 4: middle estimate off by 1.0-fold (0.01 log units), on the high side, and the stated range covers the measured number.
By their numbers in this assay, from the lowest: compounds 4, 1 and 3 (each within the scatter of the next); then compound 2.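

In this assay, the shift of the hydroxyl, a 1.3-fold lower number from compound 3 to compound 4 (0.12 log units; within the scatter), lies within the scatter, so on this aromatic carbon next to the ring nitrogen, 2-hydroxyphenyl and 3-hydroxyphenyl are not told apart when a 2-(trifluoromethyl)phenyl group is present. The group on the other side of the comparison also gains a reading: with a 1.0-fold lower number from compound 1 to compound 4 (0.00 log units; within the scatter), trifluoromethyl in place of fluoro leaves the number within the scatter, whereas a 4.9-fold lower number from compound 2 to compound 4 (0.69 log units; beyond the scatter) lies beyond it, so among the compounds shown only compound 2, with its 3-fluorophenyl group, stands apart from the rest. Nothing available bears on why these steps come out as they do.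

Whether the hydroxyl move would stay this small alongside 3-fluorophenyl or 2-fluorophenyl remains open, since the only such move shown carries 2-(trifluoromethyl)phenyl. Also open, from the compounds shown here alone, is whether the hydroxyl can be replaced at all on this aryl group, for example by a methoxy or an amino group.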